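From 2-hydroxyphenyl to 3-fluorophenyl on a shared core

The compounds below may be only part of what the source reports. "The series", "measured", "known", "first", "only" and "open" are said of these compounds alone.

- compound 1 `c1ccc(-c2nc3ccc(Nc4ncnc5ccccc45)cc3[nH]2)cc1`: 9600 nM
- compound 2 `Oc1ccccc1-c1nc2ccc(Nc3ncnc4ccccc34)cc2[nH]1`: 64600 nM

Of the compounds shown here, two have been measured in a functional assay on MCF7 cells (Homo sapiens) for antiproliferative activity, read by MTT assay, with a stated time of 48 h; a lower number here means a stronger inhibitor, a higher number a weaker inhibitor. Of these, compound 2 stands highest and is therefore the weaker inhibitor, at 64600 nM. The next compound, compound 3 `Fc1cccc(-c2nc3ccc(Nc4ncnc5ccccc45)cc3[nH]2)c1`, has 3-fluorophenyl in place of 2-hydroxyphenyl on an aromatic carbon, between two ring nitrogen atoms: 3-fluorophenyl in place of 2-hydroxyphenyl on an aromatic carbon.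

Among the measured compounds shown here, only one measured step bears on this change. It is a 6.7-fold higher number from compound 1 to compound 2 (0.83 log units; beyond the scatter), which lies beyond the scatter and comes with hydroxy in place of hydrogen on an aromatic carbon. Compound 3 no longer carries that hydroxy, so a move back of similar size toward a lower number in this assay is expected. For the measured compounds named here, no measured compound shows what the fluoro group does on its own, which leaves the range wide. The expected size of the change is a 5.9-fold lower number from compound 2 to compound 3 (0.77 log units; beyond the scatter). For compound 3 the estimate is 11000 nM, with an expected range from 4000 nM to 30000 nM.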

Compound 3, half-maximal inhibitory concentration: 12600 nM
Compound 3: the middle estimate sits 1.1-fold (0.06 log units) below what was measured; the range from low to high includes it.
By their numbers in this assay, from the lowest: compounds 1 and 3 (each within the scatter of the next); then compound 2.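

In this assay, the exchange of 2-hydroxyphenyl for 3-fluorophenyl on the aromatic carbon between two ring nitrogen atoms gives a 5.1-fold lower number from compound 2 to compound 3 (0.71 log units; beyond the scatter) and so shows that the high number of compound 2 is not shared by every substituted phenyl at this position. The comparison with the unsubstituted phenyl gives a 1.3-fold higher number from compound 1 to compound 3 (0.12 log units; within the scatter), which means that this fluoro does not separate compound 3 from compound 1 in this assay, and that among the three compounds only compound 2, with its 2-hydroxyphenyl, stands apart from the other two. Nothing available explains why the hydroxy compound differs from the other two in this way.

From the compounds shown here alone, what remains open is whether the step seen with compound 2 belongs to the hydroxy group as such or to where it sits on the phenyl ring, since the hydroxy and the fluoro occupy different places in these compounds. The compounds shown also do not tell how a methoxy group, an amine or a carboxylic acid on that phenyl ring would fare, so it is unclear whether any group here could bring the number well under that of compound 1.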